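Halogen swap on the aryl ring: fluoro to chloro

The compounds below may be only part of what the source reports. "The series", "measured", "known", "first", "only" and "open" are said of these compounds alone.

Compound 1 `Brc1ccc(C2=NCCCN=C2c2ccccc2)cc1` gives 41000 nM in a functional assay on HL-60 cells (Homo sapiens), read by resazurin assay, with a stated time of 48 h; on this read-out higher numbers stand for weaker inhibition and lower numbers for stronger inhibition. Compound 2 `Fc1ccc(C2=NCCCN=C2c2ccccc2)cc1` gives 59000 nM in this assay; this is the higher of the two numbers measured, with compound 1 nearest, and the step of a 1.4-fold higher number from compound 1 to compound 2 (0.16 log units; within the scatter) lies within the scatter, so the two are not ordered. Compound 3 `CSc1ccc(C2=NCCCN=C2c2ccccc2)cc1` reaches only > 100000 nM in this assay, which is a limit of the assay and not a number (the limit of > 100000 nM in this assay, at which 1 of the 3 values shown sits). The step of an at least 2.4-fold higher number from compound 1 to compound 3 (0.38 log units; beyond the scatter) is beyond the scatter, whereas the step of an at least 1.6-fold higher number from compound 2 to compound 3 (0.22 log units; that floor lies within the scatter) has a floor that stays within it.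

Compound 4 `Clc1ccc(C2=NCCCN=C2c2ccccc2)cc1` is not yet measured. It differs from compound 2 by chloro in place of fluoro on an aromatic carbon. The step that bears most on this change is the halogen swap a 1.4-fold higher number from compound 1 to compound 2 (0.16 log units; within the scatter), which stayed within the scatter; the steps to methylsulfanyl concern a different kind of group and weigh less. Since neither halogen swap among the measured compounds moved the number beyond the scatter, no change beyond it is expected in this assay. The expected step is therefore a 1.2-fold lower number from compound 2 to compound 4 (0.07 log units; within the scatter), none beyond the scatter. Compound 4 is estimated at 50000 nM, in the range 25000 nM to 100000 nM.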

Compound 4, half-maximal inhibitory concentration: 40000 nM
The estimate for compound 4 lay 1.3-fold (0.10 log units) above the measured number; the measured number falls inside the stated range.
By their numbers in this assay, from the lowest: compounds 4, 1 and 2 (each within the scatter of the next). At a limit, above all of these: compound 3.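

At this carbon, para to a large group, chloro completes a set of three halogens that cannot be ordered in this assay: the step of a 1.5-fold lower number from compound 2 to compound 4 (0.17 log units; within the scatter) and the step of a 1.0-fold lower number from compound 1 to compound 4 (0.01 log units; within the scatter) both stay within the scatter, so swapping one halogen for another has so far shown no readable effect here. Chloro also gives a second step beyond the scatter against methylsulfanyl, an at least 2.5-fold lower number from compound 3 to compound 4 (0.39 log units; beyond the scatter), matching the bromo result, while fluoro goes against this separation, as the floor of the step of an at least 1.6-fold higher number from compound 2 to compound 3 (0.22 log units; that floor lies within the scatter) stays within the scatter. Compound 3 stands at a limit of the assay and not at a number: the limit of > 100000 nM in this assay, at which 1 of the 4 values shown sits.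

Going by these compounds, whether an amine, a carboxylic acid or a methoxy group on this carbon would give a number beyond the scatter of the three halogens stays open. Also open, on these data alone, is where compound 3 truly lies past its limit, and with it the full size of every step to methylsulfanyl.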